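The compounds below may be only part of what the source reports. "The series", "measured", "known", "first", "only" and "open" are said of these compounds alone.

Compound 1 `Cc1ccccc1CNc1ncnn1-c1cccc(Cl)c1Cl` is the reference point of this small set. For the measured compounds named here, in a functional assay for antagonist activity at P2X purinoceptor 7 (Homo sapiens), read by FLIPR and calcium flux (a higher number here means a weaker inhibitor, a lower number a stronger inhibitor), compound 1 gives 20.9 nM, the lowest of the three numbers measured so far. Compound 2 `CCOc1ccccc1CNc1ncnn1-c1cccc(Cl)c1Cl` gives 45.7 nM in this assay, and compound 3 `CSc1ccccc1CNc1ncnn1-c1cccc(Cl)c1Cl` gives 49 nM. The step of a 2.2-fold higher number from compound 1 to compound 2 (0.34 log units; beyond the scatter) and the step of a 2.3-fold higher number from compound 1 to compound 3 (0.37 log units; beyond the scatter) both go beyond the scatter, whereas the step of a 1.1-fold higher number from compound 2 to compound 3 (0.03 log units; within the scatter) stays within it.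

Compound 4 `Cc1cccc(CNc2ncnn2-c2cccc(Cl)c2Cl)c1C` has not been measured. Relative to compound 1 the change is methyl in place of hydrogen on an aromatic carbon. Going by the values given here, none of the measured steps adds a group to the ring; each of them replaces the methyl of compound 1 with a different group, and both replacements raised the number modestly. Compound 4 keeps that methyl and gains a second one, so the measured steps bear on it only indirectly: they show that changes at this ring produce modest shifts rather than large ones. For compound 4 the expectation in this assay is therefore a step of a 1.3-fold higher number from compound 1 to compound 4 (0.13 log units; within the scatter) that may well stay within the scatter, with a slight lean toward a higher number. Compound 4 is expected to give about 28 nM in this assay, within a range from 10 nM to 75 nM.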

Compound 4, half-maximal inhibitory concentration: 67.6 nM
For compound 4 the middle estimate is 2.4-fold (0.38 log units) below the measured one; low and high end bracket the measured number.
By their numbers in this assay, from the lowest: compound 1; then compounds 2, 3 and 4 (each within the scatter of the next).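

For the compounds shown here, the earlier steps in this assay all replaced the methyl of compound 1, and this is the first to keep that methyl and fill a hydrogen-bearing aromatic carbon, ortho to a methyl group and meta to a large group. Adding just this one heavy atom gives a 3.2-fold higher number from compound 1 to compound 4 (0.51 log units; beyond the scatter), so hydrogen and methyl are not interchangeable at this carbon, and the change, though modest, is beyond the scatter. Compound 1 therefore keeps the lowest number of the set, with a replacement of its methyl and an addition to its ring each raising the number; the data offer no measured basis for explaining this rise.

The compounds shown leave open whether the rise belongs to this carbon alone or to the two methyl groups together, a question that a compound carrying only the new methyl would address. They also leave open how this carbon responds to other groups, such as fluorine, chlorine, methoxy, hydroxyl or an amine, and so whether any substituent there can match hydrogen.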